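The source may report more compounds than this note shows. Statements on the series, on what has been measured and on what is new or still open speak of the compounds shown alone.

Compound 2, with the structure `Nc1scc(CN2CCN(c3ccc(F)c(F)c3)CC2)c1C(=O)c1ccc(Cl)cc1`, stands lowest of the two numbers in hand. In a functional assay on CHO cells with adenosine receptor A1 (Homo sapiens) as the target, read by cAMP accumulation and immunoassay, with a stated time of 6 min, tested at 1 uM (a lower number here means a stronger effect, a higher number a weaker effect of the compound at the concentration tested), compound 2 gives -78%. Compound 1, with the structure `Nc1scc(CN2CCN(c3cccc4ccccc34)CC2)c1C(=O)c1ccc(Cl)cc1`, gives in this assay 2.9%, and the measured step of a number 80.9 percentage points lower from compound 1 to compound 2 (beyond the scatter) is a large one. Compound 3, with the structure `Nc1scc(CN2CCN(c3c(F)cccc3F)CC2)c1C(=O)c1ccc(Cl)cc1`, has not been measured in this assay. It differs from compound 2 in one place: 2,6-difluorophenyl in place of 3,4-difluorophenyl on an amine nitrogen in a ring. Among the measured compounds shown here, the only measured step, from compound 1 to compound 2, swaps one whole group for another on the same ring nitrogen, so it bears on the step to compound 3 only loosely; it shows that this position can move the read-out by a large amount, but nothing measured shows what rearranging the two fluorines does. The expected step of a number 38 percentage points higher from compound 2 to compound 3 (beyond the scatter) from compound 2 to compound 3 is therefore a move back toward the middle of the range. Compound 3 is estimated at -40%, with a range from -90% to 10%.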

Compound 3, a percentage reported as activity, at one concentration (the size of the read-out at that concentration, not a potency): -65%
Estimate against measurement, compound 3: 25 percentage points above; the measured number falls inside the stated range.
By their numbers in this assay, from the lowest: compound 2; then compound 3; then compound 1.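

Rearranging the two fluorines, with the same atoms kept, is enough to shift the read-out in this assay by a number 13 percentage points higher from compound 2 to compound 3 (beyond the scatter) and so the arrangement on this ring counts, if only modestly. The larger change is a number 67.9 percentage points lower from compound 1 to compound 3 (beyond the scatter) and it shows that a second difluorophenyl group, not just the 3,4-difluorophenyl group, lies far below naphthalen-1-yl on this ring nitrogen, so here the choice of group outweighs the placing of its fluorines. Nothing available explains why either change moves the read-out.

The compounds shown leave open whether a phenyl group carrying a single fluorine, a methoxy group or an amine would follow the difluorophenyl compounds or compound 1. As far as these compounds go, each read-out also comes from one concentration, so how the three compare in potency remains open.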